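This account rests on a few compounds, and the source may have more. Where it says the series, first, only, none or still open, it means among the compounds named here.

Measured compounds in a functional assay; a lower number here means a stronger inhibitor, a higher number a weaker inhibitor:
compound 1 `CC(C)=CCOc1ccc2c(c1)OC(c1ccc(Cl)cc1)CC2=O`: 6970 nM
compound 2 `COc1ccc(C2CC(=O)c3ccc(OCC=C(C)C)cc3O2)c(OC)c1`: 8180 nM

In this assay compound 1 gives 6970 nM, the lower of the two numbers recorded, and compound 2 gives 8180 nM. The two values lie within the scatter of each other, so neither compound can be set apart from the other on these numbers; both stand in the weak range of this assay.

Compound 3 `CC(C)=CCOc1ccc2c(c1)OC(c1ccc(O)cc1)CC2=O` has not yet been measured. It differs from compound 1 in one place: hydroxy in place of chloro on an aromatic carbon. Within the data shown here, no pair of measured compounds differing in a single place is available, so there is no measured step on which to size this change. Among the measured compounds shown here, the one comparison that exists, between compound 1 and compound 2, concerns a different part of the molecule and shows no movement beyond the scatter.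

On that basis the step is expected to be small, in either direction or none beyond the scatter, with a 1.1-fold higher number from compound 1 to compound 3 (0.03 log units; within the scatter) as the central expectation. Compound 3 is therefore estimated to give about 7500 nM in this assay, most likely between 3000 nM and 20000 nM.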

Compound 3, half-maximal inhibitory concentration: 6670 nM
Compound 3: the middle estimate sits 1.1-fold (0.05 log units) above what was measured; measured number inside the range.
By their numbers in this assay, from the lowest: compounds 3, 1 and 2 (each within the scatter of the next).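

In this assay, among these compounds, the change from 4-chlorophenyl to 4-hydroxyphenyl gives the first measured step at a single place: a 1.0-fold lower number from compound 1 to compound 3 (0.02 log units; within the scatter). At this position on the aromatic ring, para to a large group, a chloro with no hydrogen-bond donor or acceptor can therefore be exchanged for a hydroxy, which carries both, without the number moving beyond the scatter. No independent measurement is available to explain this result.

From the compounds shown here alone, whether an amine or a carboxylic acid at this same place would move the number beyond the scatter remains open, and a single exchange cannot show whether this position is insensitive to substitution in general. With compounds 3, 1 and 2 each within the scatter of the next in this assay, the compounds shown also leave open which part of the molecule, if any, could take the series out of its weak range.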